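The source may report more compounds than this note shows. Statements on the series, on what has been measured and on what is new or still open speak of the compounds shown alone.

Working notes on the amide series.

Compound 1 `N[C@H]1CCCN(C(=O)c2ccc(-c3ccc4ncc(-c5ccc6cnccc6c5)n4c3)cc2)C1` is the reference point. In an assay on Sf21 cells for inhibition of MAP kinase-interacting serine/threonine-protein kinase 1 (Homo sapiens), read by luminescence and ADP-Glo, with stated times of 10 min and 40 min (a lower number here means a stronger inhibitor, a higher number a weaker inhibitor), compound 1 gives 2.5 nM, the lowest of the two numbers in hand. Compound 2 `NC1CCN(C(=O)c2ccc(-c3ccc4ncc(-c5ccc6cnccc6c5)n4n3)cc2)CC1` differs from compound 1 in more than one place, so no single step can be read between them; in this assay compound 2 gives 14.5 nM, which lies beyond the scatter from compound 1 on the weaker side.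

Compound 3 `O=C(c1ccc(-c2ccc3ncc(-c4ccc5cnccc5c4)n3c2)cc1)N1CCOCC1` carries the change (morpholin-4-yl in place of 3-aminopiperidin-1-yl on a carbonyl carbon). The group that leaves carries the only hydrogen-bond donor on that end of the amide; the group that enters brings none. Within the data shown here, no measured pair on this series shows the same change, so the size of the step is open. The expectation is a moderate weakening from compound 1 to compound 3 in this assay, beyond the usual scatter, as a 4.8-fold higher number from compound 1 to compound 3 (0.68 log units; beyond the scatter). Compound 3 is therefore estimated at 12 nM, with a range from 3 nM to 50 nM.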

Compound 3, half-maximal inhibitory concentration: 7 nM
Estimate against measurement, compound 3: 1.7-fold (0.23 log units) above; the measured number falls inside the stated range.
By their numbers in this assay, from the lowest: compound 1; then compound 3; then compound 2.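

In this assay, among these compounds, the first single-place step on this series reads a 2.8-fold higher number from compound 1 to compound 3 (0.45 log units; beyond the scatter) and is modest, though beyond the scatter. The amino group on the 3-aminopiperidin-1-yl is therefore not required for a low number on this carbonyl carbon, since compound 3 still gives 7 nM with morpholin-4-yl and its 0 hydrogen-bond donors. Nothing in hand gives a reason for the size of this step.

From the compounds shown here alone, the change swaps the amino group, the ring oxygen and the stereocentre together, so their shares cannot be separated; whether 3-hydroxypiperidin-1-yl or piperazin-1-yl would sit nearer compound 1 or compound 3 stays open. Also open, going by these compounds, is whether the same change gives a similar step on the core of compound 2.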